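This account rests on a few compounds, and the source may have more. Where it says the series, first, only, none or still open, it means among the compounds named here.

In an ADME assay on cells (Fibroblast, Gallus gallus) for cytotoxicity, read by CCK-8 assay, with a stated time of 48 h (a lower number here means that less compound is tolerated, a higher number that more compound is tolerated), compound 1 (`CCC(CC)O[C@@H]1C=C(C(=O)O)C[C@H](NCc2ccc(C(C)(C)C)cc2)[C@H]1NC(C)=O`) gives > 200000 nM which is a limit of the assay and not a number. Compound 2 (`CCC(CC)O[C@@H]1C=C(C(=O)O)C[C@H](NCc2ccc(-c3csc4ccccc34)cc2)[C@H]1NC(C)=O`) likewise gives > 200000 nM which is also a limit and not a number. Compound 2 therefore has no exact value, and the record so far amounts to the limit of > 200000 nM in this assay, at which 2 of the 2 values shown sit, alone. Compound 3 (`CCC(CC)O[C@@H]1C=C(C(=O)O)C[C@H](NCc2ccc(-c3ccc4sccc4c3)cc2)[C@H]1NC(C)=O`) has the same atoms as compound 2, joined differently, with the change given by 1-benzothiophen-5-yl in place of 1-benzothiophen-3-yl on an aromatic carbon and placed para to a large group. Going by the values given here, the only measured step that bears on it is a step that the two limits leave unreadable from compound 1 to compound 2 and this gives no size to carry over. No step beyond the usual scatter is therefore expected in this assay in either direction. The expected change is a number no higher from compound 2 to compound 3 (the limit leaves the size open) and it has no predicted direction. For compound 3 the estimated value is 200000 nM with an expected range from 120000 nM to 300000 nM and a report of only a limit is the likeliest outcome.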

Compound 3, half-maximal cytotoxic concentration: > 200000 nM
Compound 3: a limit, no number (the forecaster's own chance of this, stated with the estimate: 85%); the middle value lies on the limit itself.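

In this assay, going by these compounds alone, compound 3 gives > 200000 nM, a limit of the assay and not a number, so no step from compound 1 or compound 2 to compound 3 can be read. From the compounds shown here alone, whether the three compounds differ in this assay stays open.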